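The compounds below may be only part of what the source reports. "The series", "measured", "known", "first", "only" and "open" are said of these compounds alone.

Compound 1 `COc1cc2c(Oc3ccc(NC(=O)c4nn(-c5ccccc5F)c(=O)c5ccccc45)cc3F)ccnc2cc1OCCCN1CCCC1`: 400 nM
Compound 2 `COc1cc2c(Oc3ccc(NC(=O)c4nn(-c5ccccc5)c(=O)c5ccccc45)cc3F)ccnc2cc1OCCCN1CCN(C)CC1`: 1140 nM
Compound 3 `COc1cc2c(Oc3ccc(NC(=O)c4nn(-c5ccccc5F)c(=O)c5ccccc45)cc3F)ccnc2cc1OCCCN1CCN(C)CC1`: 480 nM

In a functional assay on HT-29 cells (Homo sapiens) for cytotoxicity, read by MTT assay, with a stated time of 72 h (a lower number here means a stronger inhibitor, a higher number a weaker inhibitor), compound 3 gives 480 nM, the second highest of the three numbers; compound 1 lies within the scatter of it, while compound 2 gives 1140 nM, separated from it by a 2.4-fold lower number from compound 2 to compound 3 (0.38 log units; beyond the scatter). Compound 4 `COc1cc2c(Oc3ccc(NC(=O)c4nn(-c5ccc([N+](=O)[O-])cc5)c(=O)c5ccccc45)cc3F)ccnc2cc1OCCCN1CCN(C)CC1` differs from compound 3 by 4-nitrophenyl in place of 2-fluorophenyl on an aromatic nitrogen. Among the compounds with values here, the only measured step that touches this part of the shared core is a 2.4-fold lower number from compound 2 to compound 3 (0.38 log units; beyond the scatter), a modest move; the step of a 1.2-fold higher number from compound 1 to compound 3 (0.08 log units; within the scatter) concerns a different part of the structure and does not bear on the change. Within the data shown here, compound 4 gives up that fluorine, and the nitro group has no measured precedent here, so a modest rise beyond the scatter is expected, a 1.9-fold higher number from compound 3 to compound 4 (0.27 log units; within the scatter). Compound 4 is therefore estimated at 900 nM, in a range from 300 nM to 2700 nM.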

Compound 4, half-maximal inhibitory concentration: 2560 nM
Compound 4: the middle estimate sits 2.8-fold (0.45 log units) below what was measured; the range from low to high includes it.
By their numbers in this assay, from the lowest: compounds 1 and 3 (each within the scatter of the next); then compound 2; then compound 4.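

In this assay, adding nitro to the unsubstituted phenyl of compound 2 pushes the number the opposite way from fluoro, a 2.2-fold higher number from compound 2 to compound 4 (0.35 log units; beyond the scatter). Exchanging 2-fluorophenyl for 4-nitrophenyl therefore gives the largest step yet seen at this position, a 5.3-fold higher number from compound 3 to compound 4 (0.73 log units; beyond the scatter). No measurement available here accounts for either shift.

A 4-fluorophenyl or 2-nitrophenyl compound would help separate the effect of the group from that of its place on the ring. A 4-aminophenyl compound would test a different group at the position occupied by nitro.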